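The source may report more compounds than this note shows. Statements on the series, on what has been measured and on what is new or still open speak of the compounds shown alone.

Compound 2, `COc1cc(CC(C)C(=O)N2CCN(c3ccc(C(F)(F)F)cc3[C@@H](N)CC(C)C)CC2)ccc1Cl`, gives 230 nM in an assay on HEK293 cells for displacement of a labelled ligand from Melanocortin receptor 4 (Homo sapiens); on this read-out lower numbers stand for stronger inhibition and higher numbers for weaker inhibition. Compound 1, `CC(C)C[C@H](N)c1cc(C(F)(F)F)ccc1N1CCN(C(=O)COc2ccc3ccccc3c2)CC1`, gives 2000 nM in this assay.

Of the two measured compounds, compound 2 stands at the lower number; the gap between them is an 8.7-fold lower number from compound 1 to compound 2 (0.94 log units; beyond the scatter), which lies beyond the scatter. Compound 3, `CC(C)C[C@H](N)c1cc(C(F)(F)F)ccc1N1CCN(C(=O)CCC(N)=O)CC1`, has not yet been measured. It differs from compound 2 in one place: 2-carbamoylethyl in place of 1-(4-chloro-3-methoxybenzyl)ethyl on a carbonyl carbon. Among the compounds with values here, the only measured step that bears on this position is an 8.7-fold lower number from compound 1 to compound 2 (0.94 log units; beyond the scatter), where one aromatic group replaced another on the same carbonyl carbon. Within the data shown here, compound 3 instead carries a short chain with no ring there, which no measured step covers directly. The expectation is that compound 3 gives a higher number than compound 2, with a step of about a 13-fold higher number from compound 2 to compound 3 (1.12 log units; beyond the scatter). Compound 3 is therefore estimated at 3000 nM in this assay, within a range from 600 nM to 20000 nM.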

Compound 3, inhibition constant: > 10000 nM
Compound 3 ended at the assay's limit; the forecaster's own chance of this, stated with the estimate: 25%; middle value at least 3.3-fold (0.52 log units) away from the limit.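

The reading for compound 3 is a limit of the assay and not a number: the limit of > 10000 nM in this assay, at which 1 of the 3 values shown sits. Even so, 2-carbamoylethyl in place of 1-(4-chloro-3-methoxybenzyl)ethyl gives an at least 43-fold higher number from compound 2 to compound 3 (1.63 log units; beyond the scatter), so a group with no ring on this carbonyl carbon reaches much further up the scale than the earlier swap between two aromatic groups did. Carbamoylmethyl in place of (naphthalen-2-yl)oxy also gives an at least 5.0-fold higher number from compound 1 to compound 3 (0.69 log units; beyond the scatter), so both ring-bearing compounds stand at lower numbers than compound 3.

The compounds shown do not separate the departure of the aromatic ring from the arrival of the primary amide. Going by these compounds, how a plain alkyl chain without the amide, or a benzyl group without the chlorine and methoxy, would read on this carbonyl carbon stays open.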